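Removing the ring methyl from the sulfonyl group of compound 1

The source may hold more compounds than are shown below. What is called first, only, known or untested is meant among the compounds shown, and "the series" means these compounds.

Of the compounds shown here, three built on one shared core have been measured in a functional assay for inhibition, read by spectrophotometry, with a stated time of 20 min, tested at 2 mg/mL; on this read-out higher numbers stand for a stronger effect at the one concentration tested and lower numbers for a weaker effect. Compound 1 `CC(=O)c1ccc(NC(=O)C(CC(C)C)N(C(=O)c2ccccc2)S(=O)(=O)c2ccc(C)cc2)cc1` gives 58.1% and stands highest of the three numbers. Compound 2 `CCC(C)C(C(=O)Nc1ccc(C(C)=O)cc1)N(C(=O)c1ccccc1)S(=O)(=O)c1ccc(C)cc1` gives 25.7%, and compound 3 `CC(=O)c1ccc(NC(=O)C(C(C)C)N(C(=O)c2ccccc2)S(=O)(=O)c2ccc(C)cc2)cc1` gives 22.7%. The two measured steps away from compound 1 are both large: a number 32.4 percentage points lower from compound 1 to compound 2 (beyond the scatter) and a number 35.4 percentage points lower from compound 1 to compound 3 (beyond the scatter), each beyond the scatter, while a number 3 percentage points lower from compound 2 to compound 3 (within the scatter) lies within it. Every one of these steps changes the branched chain on the saturated carbon bound to the amide-type nitrogen and the carbonyl carbon.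

Compound 4 `CC(=O)c1ccc(NC(=O)C(CC(C)C)N(C(=O)c2ccccc2)S(=O)(=O)c2ccccc2)cc1` differs from compound 1 elsewhere: hydrogen in place of methyl on an aromatic carbon. Among the measured compounds shown here, no measured step touches the aromatic ring of the sulfonyl group, so the measured steps do not bear on this change; they only show that the read-out in this assay is sensitive to the chain and say nothing about the ring. With no guidance from the measured pairs, the expected step is taken as none beyond the scatter, a number 6.1 percentage points lower from compound 1 to compound 4 (within the scatter), and the range is kept wide. Compound 4 is therefore estimated to give 52% in this assay, between 30% and 70%.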

Compound 4, a percentage reported as inhibition, at one concentration (the size of the read-out at that concentration, not a potency): 33.7%
Estimate against measurement, compound 4: 18.3 percentage points above, and the stated range covers the measured number.
By their numbers in this assay, from the lowest: compounds 3, 2 and 4 (each within the scatter of the next, the first and the last beyond it); then compound 1.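

In this assay, among the compounds shown here, the change from (4-methylphenyl)sulfonyl to phenylsulfonyl gives a number 24.4 percentage points lower from compound 1 to compound 4 (beyond the scatter) and so shows that the read-out responds to this aromatic carbon as well as to the branched chain, the only part varied among the earlier compounds. Replacing this one methyl, a single heavy atom, with hydrogen is enough to produce a step beyond the scatter, so the higher number of compound 1 depends on this methyl as well as on its isobutyl chain. No accompanying evidence bears on this step, and what lies behind it remains unexplained.

The compounds shown leave open whether a chlorine, a methoxy group or a longer chain such as ethyl or propyl at this position would hold the number near that of compound 1, or take it higher or lower still. They also leave open whether removing this methyl would produce a step of similar size with the sec-butyl chain of compound 2 or the isopropyl chain of compound 3 in place of the isobutyl chain.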